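A few compounds are considered here, and "the series" means these few. Any claim that something is new, unique, unknown or untested is made for them only; others in the source may bear on it.

Measured in an ADME assay on Vero cells (Chlorocebus sabaeus) for cytotoxicity, read by CellTiter-Glo, with a stated time of 72 h; on this read-out higher numbers stand for lower toxicity in this test and lower numbers for higher toxicity in this test:
- Compound 1 `[O-][n+]1nc(NC2CCC2)[n+]([O-])c2ccccc21`: 8.9 ug/mL
- Compound 2 `[O-][n+]1nc(NC2CCC2)[n+]([O-])c2ccc(F)cc21`: 1.6 ug/mL

Of these two numbers, compound 2 has the lower, 1.6 ug/mL, so it is the more toxic in this assay. Compound 3 `[O-][n+]1nc(N[C@@H]2C[C@H]3CC[C@@H]2C3)[n+]([O-])c2ccc(F)cc21` keeps the rest of compound 2 but changes one group: a group of 7 heavy atoms (7 carbon; 2 five-membered non-aromatic rings of carbon only) in place of a group of 4 heavy atoms (4 carbon; one four-membered non-aromatic ring of carbon only), on a nitrogen on an aromatic ring. Within the data shown here, the only measured step, a 5.6-fold lower number from compound 1 to compound 2 (0.75 log units; beyond the scatter), is modest but beyond the scatter. It comes from fluoro in place of hydrogen on an aromatic carbon, so it says nothing directly about this new group. No direction can be drawn from it. The expected change is a 1.1-fold lower number from compound 2 to compound 3 (0.03 log units; within the scatter), which means no step beyond the scatter. For compound 3 the estimated value is 1.5 ug/mL, with an expected range of 0.5 ug/mL to 4.5 ug/mL.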

Compound 3, half-maximal cytotoxic concentration: < 2.5 ug/mL
Compound 3: a limit, no number; the forecaster's own chance of this, stated with the estimate: 5%; the middle value is on the limit's open side.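

Compound 3 gives < 2.5 ug/mL, which is a limit and not a number, so the step from compound 2 to compound 3 cannot be read. The compounds shown leave open whether replacing cyclobutyl with the group of 7 heavy atoms changes toxicity, and in which direction.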